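Swapping a chlorophenyl arm for a methylthiophene

The compounds below may be only part of what the source reports. "The series", "measured", "known", "first", "only" and "open" are said of these compounds alone.

Of the compounds shown here, two of a shared core have been tested in a functional assay on MCF7 cells (Homo sapiens) for cytotoxicity, read by CellTiter-Glo, with a stated time of 5 days; a lower number here means a stronger inhibitor, a higher number a weaker inhibitor. Compound 1 `CC/C(=C(/c1ccc(/C=C/C(=O)O)cc1)c1cccc2[nH]ncc12)c1ccccc1` gives 21 nM in this assay. Compound 2 `CC/C(=C(/c1ccc(/C=C/C(=O)O)cc1)c1ccc2[nH]ncc2c1)c1cccc(Cl)c1` gives 12 nM in this assay, the lower of the two numbers, although its gap to compound 1 lies within the usual scatter, so the two cannot be ranked.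

Compound 3 `CC/C(=C(/c1ccc(/C=C/C(=O)O)cc1)c1ccc2[nH]ncc2c1)c1cscc1C` has not yet been measured in this assay. It differs from compound 2 in one place: 4-methylthiophen-3-yl in place of 3-chlorophenyl on a double-bonded chain carbon bound to a double-bonded chain carbon and a saturated chain carbon. No step between measured compounds bears on this change, so there is no shown precedent to lean on. The expectation is therefore a step of only modest size from compound 2 to compound 3 in this assay, leaning slightly toward a higher number, amounting to a 1.7-fold higher number from compound 2 to compound 3 (0.22 log units; within the scatter). Compound 3 is thus estimated at 20 nM, with a likely range from 8 nM to 50 nM.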

Compound 3, half-maximal inhibitory concentration: 2 nM
Beside the measured number, compound 3's estimate is 10-fold (1.00 log units) above it, and the stated range ends above it.
By their numbers in this assay, from the lowest: compound 3; then compounds 2 and 1 (each within the scatter of the next).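

Putting 4-methylthiophen-3-yl in place of 3-chlorophenyl gives a 6.0-fold lower number from compound 2 to compound 3 (0.78 log units; beyond the scatter) in this assay at this place on the chain, so the arm on the double-bonded chain carbon can move the number by more than the scatter. The arm that enters has a five-membered aromatic ring with 1 hetero atom and 1 hydrogen-bond acceptor, while the arm that leaves has a six-membered aromatic ring of carbon only and no acceptor. No measurement at hand explains why the number falls.

This single step changes the ring and its substituent together, which leaves open whether the thiophene ring or its methyl accounts for the drop. A plain thiophen-3-yl and a methylphenyl arm would help to tell these two apart.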